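Replacing the 2-methylphenyl Group of Compound 3

A few compounds are considered here, and "the series" means these few. Any claim that something is new, unique, unknown or untested is made for them only; others in the source may bear on it.

Three related compounds have been tested so far in a functional assay on MCF7 cells (Homo sapiens) for cytotoxicity, read by CellTiter-Glo, with a stated time of 5 days; on this read-out lower numbers stand for stronger inhibition and higher numbers for weaker inhibition. Compound 1 (`CC/C(=C(/c1ccc(/C=C/C(=O)O)cc1)c1ccc(NS(C)(=O)=O)cc1)c1ccccc1`) gives 2310 nM, compound 2 (`CC/C(=C(/c1ccc(/C=C/C(=O)O)c(OC)c1)c1ccc2[nH]ncc2c1)c1ccccc1`) gives 31 nM, and compound 3 (`CC/C(=C(/c1ccc(/C=C/C(=O)O)cc1)c1ccc2[nH]ncc2c1)c1ccccc1C`) gives 4 nM. Compound 3 thus has the lowest number of the three, and its gaps to both others lie beyond the usual scatter, so it is the most potent so far.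

Compound 4 (`CC/C(=C(/c1ccc(/C=C/C(=O)O)cc1)c1ccc2[nH]ncc2c1)c1ccncc1Cl`) has 3-chloropyridin-4-yl in place of 2-methylphenyl on a double-bonded chain carbon bound to a double-bonded chain carbon and a saturated chain carbon. For the measured compounds named here, no two measured compounds differ in one place only, so the data offer no direct guide to this change. With compound 3 as the starting point at 4 nM, a modest weakening is the cautious expectation. The expected change is a 2.5-fold higher number from compound 3 to compound 4 (0.40 log units; beyond the scatter), towards a higher number. In this assay, the estimate for compound 4 is 10 nM, with an expected range from 2.5 nM to 40 nM.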

Compound 4, half-maximal inhibitory concentration: 4 nM
Compound 4: the middle estimate sits 2.5-fold (0.40 log units) above what was measured; low and high end bracket the measured number.
By their numbers in this assay, from the lowest: compounds 3 and 4 (each within the scatter of the next); then compound 2; then compound 1.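

In this assay, for the compounds shown here, putting 3-chloropyridin-4-yl in place of 2-methylphenyl gives no change at the digits printed from compound 3 to compound 4 (within the scatter), the first direct reading of a single change. At this place, on a double-bonded chain carbon bound to a double-bonded chain carbon and a saturated chain carbon, a ring of carbon only can thus give way to a six-membered aromatic ring with 1 hetero atom and 1 hydrogen-bond acceptor without a measurable change in this assay. Nothing available explains why the number holds steady.

As far as these compounds go, the swap brings in the ring nitrogen and the chlorine together, so the contribution of each remains unknown. From the compounds shown here alone, it also remains open how a saturated group such as cyclohexyl, or a ring carrying an amine, would behave at this place.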